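Trimethoxyphenyl replacement at the saturated ring carbon

The source may report more compounds than this note shows. Statements on the series, on what has been measured and on what is new or still open speak of the compounds shown alone.

Measured compounds:
compound 1 `Cc1cc(O)c(C2=NN(c3ccc(S(N)(=O)=O)cc3)C(c3ccccc3Cl)C2)cc1Cl`: 5800 nM
compound 2 `Cc1cc(O)c(C2=NN(c3ccc(S(N)(=O)=O)cc3)C(/C=C/c3ccccc3)C2)cc1Cl`: 40300 nM

In a functional assay on LOX IMVI cells (Homo sapiens) for antiproliferative activity, with a stated time of 48 h (on this read-out lower numbers stand for higher toxicity in this test and higher numbers for lower toxicity in this test), compound 2 gives 40300 nM and compound 1 gives 5800 nM. Compound 2 stands highest of the two numbers; the nearest is compound 1, reached by a 6.9-fold higher number from compound 1 to compound 2 (0.84 log units; beyond the scatter).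

Compound 3 `COc1ccc(C2CC(c3cc(Cl)c(C)cc3O)=NN2c2ccc(S(N)(=O)=O)cc2)c(OC)c1OC` differs from compound 2 by 2,3,4-trimethoxyphenyl in place of 2-phenylethenyl on a saturated ring carbon. For the measured compounds named here, the only step that bears on it is the one from compound 1 to compound 2, where a 2-phenylethenyl group on that saturated ring carbon went with the higher number; compound 3 returns to a phenyl group directly on that carbon, although one bearing three methoxy groups rather than a chlorine, so the step back is expected only in part. A modest lowering in this assay is therefore expected, as a 3.4-fold lower number from compound 2 to compound 3 (0.53 log units; beyond the scatter). Compound 3 is estimated at 12000 nM, with a range from 3500 nM to 40000 nM.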

Compound 3, concentration lethal to 50% of the cells: 8840 nM
Compound 3: the middle estimate sits 1.4-fold (0.13 log units) above what was measured; measured number inside the range.
By their numbers in this assay, from the lowest: compounds 1 and 3 (each within the scatter of the next); then compound 2.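

In this assay the saturated ring carbon shows a 4.6-fold lower number from compound 2 to compound 3 (0.66 log units; beyond the scatter) when 2,3,4-trimethoxyphenyl replaces 2-phenylethenyl, so the lower number seen with 2-chlorophenyl is not confined to that one group. Against 2-chlorophenyl the same change gives a 1.5-fold higher number from compound 1 to compound 3 (0.18 log units; within the scatter), so compounds 1 and 3 cannot be told apart in this test although one ring carries a chlorine and the other three methoxy groups; across these three compounds, a substituted phenyl directly on this carbon goes with lower numbers than 2-phenylethenyl, and none goes against this. No evidence at hand accounts for this difference.

Open, from the compounds shown here alone, is whether an unsubstituted phenyl, a single methoxy group or a saturated chain on this carbon would fall with compounds 1 and 3 or with compound 2. Open too, going by these compounds, is whether a ring-bearing group set apart from this carbon by a two-carbon saturated chain, rather than the double bond of 2-phenylethenyl, would follow compound 2.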